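The compounds below may be only part of what the source reports. "The series", "measured", "known", "first", "only" and "open" are said of these compounds alone.

Compound 1 `COc1ccc(CNc2nc3cc(N)cc(N)c3nc2-c2ccccc2)cc1OC`: in a functional assay on SW-620 cells (Homo sapiens) for inhibition, read by sulforhodamine B assay, with a stated time of 48 h (on this read-out lower numbers stand for stronger inhibition of growth and higher numbers for weaker inhibition of growth), compound 1 gives 5250 nM.
Compound 2 `Nc1cc(N)c2nc(-c3ccccc3)c(NCc3ccc(F)cc3)nc2c1`: in this assay compound 2 gives 2190 nM.

For the measured compounds named here, compound 2 stands lowest of the two numbers; the only neighbour is compound 1, and the step of a 2.4-fold lower number from compound 1 to compound 2 (0.38 log units; beyond the scatter) separates them. Compound 3 `COc1ccc(CNc2nc3cc(N)cc(N)c3nc2-c2ccccc2)cc1` differs from compound 2 by methoxy in place of fluoro on an aromatic carbon, placed on an aromatic carbon of a six-membered aromatic ring of carbon only, para to a large group. Going by the values given here, only the step of a 2.4-fold lower number from compound 1 to compound 2 (0.38 log units; beyond the scatter) bears on this change, and it ran the other way, so a partial return toward compound 1 seems plausible. Compound 3 is therefore expected to show a modest rise, a 1.6-fold higher number from compound 2 to compound 3 (0.20 log units; within the scatter), giving an estimate of 3500 nM with a range of 1800 nM to 7000 nM.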

Compound 3, concentration for 50% growth inhibition: 12900 nM
The estimate for compound 3 lay 3.7-fold (0.57 log units) below the measured number, outside the stated range (above it).
By their numbers in this assay, from the lowest: compound 2; then compound 1; then compound 3.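

In this assay, the methoxy for fluoro change at this aromatic carbon proves a large penalty, a 5.9-fold higher number from compound 2 to compound 3 (0.77 log units; beyond the scatter). For the compounds shown here, removing one methoxy from the dimethoxy compound also raises the number, a 2.5-fold higher number from compound 1 to compound 3 (0.39 log units; beyond the scatter), so the single methoxy of compound 3 does not fall between the other two compounds. Nothing available explains either step. Going by these compounds, it remains open how an amine or a hydroxyl group would compare on this aromatic carbon, and whether a longer chain in place of the methoxy would change the number.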